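The compounds below may be only part of what the source reports. "The series", "measured", "known", "first", "only" and "open" are said of these compounds alone.

Working notes on the series. In an assay on CHO cells with metabotropic glutamate receptor 2 (Homo sapiens) as the target, read by FLIPR (a lower number here means that less compound is needed, a higher number that more compound is needed for the effect), compound 1 `CCCn1c(CN2CCN(c3nc(Cl)ccc3C(F)(F)F)CC2)nc2ccccc21` gives 2510 nM, the highest of the two numbers shown; compound 3 `Cn1c(CN2CCN(c3nc4ccccc4s3)CC2)nc2ccccc21` gives 316 nM, a gap beyond the scatter. For compound 2 `Cn1c(CN2CCC(c3ccccn3)CC2)nc2ccccc21` this assay reports only a limit, > 3160 nM. One of the three values shown is such a limit (the limit of > 3160 nM in this assay, at which 1 of the 3 values shown sits). Compound 4 `FC(F)(F)c1ccc(Cl)nc1N1CCN(Cc2nc3ccccc3n2Cc2ccccc2)CC1` is still to be measured in this assay; it differs from compound 1 by phenyl in place of ethyl on a saturated chain carbon bound to an aromatic nitrogen. Among the compounds with values here, no measured pair shows this change, so its direction is open; a shift within the scatter, or at most a modest one in either direction, is expected. The step this implies, a 1.6-fold lower number from compound 1 to compound 4 (0.20 log units; within the scatter), is an estimate only. Compound 4 is expected at 1600 nM, with a range from 400 nM to 6300 nM.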

Compound 4, half-maximal effective concentration: 126 nM
Beside the measured number, compound 4's estimate is 13-fold (1.10 log units) above it, outside the stated range (below it).
By their numbers in this assay, from the lowest: compound 4; then compound 3; then compound 1. At a limit, above all of these: compound 2.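

In this assay, the place on a saturated chain carbon bound to an aromatic nitrogen responds strongly to the group it carries: phenyl in place of ethyl, which also reads as propyl to benzyl, gives a 20-fold lower number from compound 1 to compound 4 (1.30 log units; beyond the scatter). This first matched pair sets the direction of the change, towards less compound needed for the effect. Nothing shown accounts for the step.

A single pair leaves open whether the aromatic ring itself matters or whether the added carbons alone suffice. On these data alone, a cyclohexylmethyl group or a longer chain such as pentyl at this place would separate the two, and the effect of an amine or a carboxylic acid on the benzyl ring remains open.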